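The compounds below may be only part of what the source reports. "The series", "measured", "known", "first", "only" and "open" are said of these compounds alone.

Measured so far:
- compound 1, `CN(C(=O)NC(=O)c1ccccc1F)c1nc(C(F)(F)F)c(C(=O)N/N=C/c2ccc(C(F)(F)F)cc2)s1`: 3.97 ug/mL
- compound 2, `CN(C(=O)NC(=O)c1ccccc1F)c1nc(C(F)(F)F)c(C(=O)N/N=C/c2ccccc2C(F)(F)F)s1`: 10.1 ug/mL
- compound 3, `Cc1nc(N(C)C(=O)NC(=O)c2c(F)cccc2F)sc1C(=O)N/N=C/c1ccccc1C(F)(F)F`: 6.51 ug/mL

In a functional assay on HeLa cells (Homo sapiens) for inhibition, read by MTT assay, with a stated time of 72 h (on this read-out higher numbers stand for weaker inhibition and lower numbers for stronger inhibition), compound 2 gives the highest of the three numbers. Compound 3 sits nearest to it, and the gap between the two is within the scatter, so the two cannot be told apart. Compound 1 sits furthest away, and the step of a 2.5-fold higher number from compound 1 to compound 2 (0.41 log units; beyond the scatter) is beyond the scatter, so the move of the trifluoromethyl group on the imine-bearing ring weakened inhibition to a modest degree.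

Compound 4, `CN(C(=O)NC(=O)c1cccc([N+](=O)[O-])c1)c1nc(C(F)(F)F)c(C(=O)N/N=C/c2ccccc2C(F)(F)F)s1`, has not yet been measured in this assay. It comes from compound 2 by a change at the other end of the molecule: 3-nitrophenyl in place of 2-fluorophenyl on a carbonyl carbon. Going by the values given here, no measured step addresses this part of the structure. Among the compounds with values here, the only step on record, a 2.5-fold higher number from compound 1 to compound 2 (0.41 log units; beyond the scatter), concerns the imine-bearing ring and says nothing about the carbonyl-bearing ring. Compound 3 differs from compound 2 in two places at once, so its value gives no clean reading either. Within the data shown here, with no bearing step to lean on, the expectation for compound 4 is a number close to that of compound 2, with the step of a 1.0-fold lower number from compound 2 to compound 4 (0.00 log units; within the scatter) expected to stay within the scatter. Compound 4 is therefore estimated at 10 ug/mL, in a range from 4 ug/mL to 25 ug/mL.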

Compound 4, half-maximal inhibitory concentration: 4.15 ug/mL
Beside the measured number, compound 4's estimate is 2.4-fold (0.38 log units) above it; the measured number falls inside the stated range.
By their numbers in this assay, from the lowest: compounds 1, 4, 3 and 2 (each within the scatter of the next, the first and the last beyond it).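

In this assay, going by these compounds alone, the step of a 2.4-fold lower number from compound 2 to compound 4 (0.39 log units; beyond the scatter) gives the first reading at the carbonyl end of the molecule. Within the data shown here, it shows that the number responds to the group on the carbonyl carbon, and not only to the imine-bearing ring, since the earlier clean step covered only that ring. Because 3-nitrophenyl differs from 2-fluorophenyl in both the group it carries and that group's place on the ring, this single step cannot separate the two changes, and nothing measured here accounts for the shift in this cell assay.

The compounds shown leave open whether a plain phenyl ring on the carbonyl carbon would read closer to compound 2 or to compound 4, and whether an amine or a carboxylic acid in place of the nitro group would keep the lower number. They also leave open whether the same swap would give a step of similar size on a molecule carrying 4-(trifluoromethyl)phenyl at the imine end, as compound 1 does.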